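A ring methyl carried from one core to another

The source may report more compounds than this note shows. Statements on the series, on what has been measured and on what is new or still open speak of the compounds shown alone.

Compound 1 `COc1cc2c(Oc3ccc(NC(=O)c4nnn(-c5ccccc5C)c4C)cc3F)ccnc2cc1OCCCN1CCCCC1` serves as the starting point. In a functional assay on HT-29 cells (Homo sapiens) for cytotoxicity, read by MTT assay, with a stated time of 72 h (on this read-out higher numbers stand for weaker inhibition and lower numbers for stronger inhibition), compound 1 gives 450 nM. Compound 3 `COc1cc2c(Oc3ccc(NC(=O)c4nnn(-c5ccccc5C)c4C)cc3F)ccnc2cc1OCCCN1CCC(C)CC1` carries methyl in place of hydrogen on a saturated ring carbon; in this assay compound 3 gives 520 nM, and the step of a 1.2-fold higher number from compound 1 to compound 3 (0.06 log units; within the scatter) is recorded. Compound 2 `COc1cc2c(Oc3ccc(NC(=O)c4nnn(-c5ccc(F)cc5)c4C(F)(F)F)cc3F)ccnc2cc1OCCCN1CCCCC1` differs from compound 1 in its core, a difference that is not broken down here; in this assay compound 2 gives 150 nM, the lowest of the three numbers. Compound 4 `COc1cc2c(Oc3ccc(NC(=O)c4nnn(-c5ccc(F)cc5)c4C(F)(F)F)cc3F)ccnc2cc1OCCCN1CCC(C)CC1` has not been measured. It stands to compound 2 as compound 3 stands to compound 1, with methyl in place of hydrogen on a saturated ring carbon, the same change at the same place. Because the earlier step of a 1.2-fold higher number from compound 1 to compound 3 (0.06 log units; within the scatter) stayed within the scatter, compound 4 is expected to show a step of about a 1.2-fold higher number from compound 2 to compound 4 (0.08 log units; within the scatter) in this assay. Compound 4 is therefore estimated at 180 nM, with an expected range from 90 nM to 360 nM.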

Compound 4, half-maximal inhibitory concentration: 160 nM
Estimate against measurement, compound 4: 1.1-fold (0.05 log units) above; low and high end bracket the measured number.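

In this assay, the change from piperidin-1-yl to 4-methylpiperidin-1-yl on the core of compound 2 gives a 1.1-fold higher number from compound 2 to compound 4 (0.03 log units; within the scatter), so this core, too, shows no step beyond the scatter. The change carried over between the two cores with no difference between its two steps: the same change on two cores in this assay, a 1.2-fold higher number (0.06 log units; within the scatter) from compound 1 to compound 3 and a 1.1-fold higher number (0.03 log units; within the scatter) from compound 2 to compound 4, 1.1-fold (0.03 log units) apart, within the scatter of two such steps. This shows only that the methyl leaves the number unmoved on these two cores in this assay; it does not show that the same would hold on any other core or in any other assay.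

The compounds shown leave open whether a hydroxyl, an amine or a carboxylic acid in place of the methyl on the same ring carbon would behave in the same way. They also leave open whether a larger alkyl group, such as a tert-butyl, would be equally without effect there.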